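Swapping the benzyl aryl group: what to expect for compound 4

The compounds below may be only part of what the source reports. "The series", "measured", "known", "first", "only" and "open" are said of these compounds alone.

Compound 3 `Cc1ccc(CSc2cc(Cl)c(C)cc2S(=O)(=O)/N=C(\N)n2nccc2-c2ccccc2)cc1` stands highest of the three numbers in a functional assay on HeLa cells (Homo sapiens) for cytotoxicity, read by MTT assay, with a stated time of 72 h (on this read-out higher numbers stand for weaker inhibition and lower numbers for stronger inhibition), giving 17000 nM; compound 1 `Cc1cccc(CSc2cc(Cl)c(C)cc2S(=O)(=O)/N=C(\N)n2nccc2-c2ccccc2)c1` gives 8000 nM and compound 2 `Cc1cc(S(=O)(=O)/N=C(\N)n2nccc2-c2ccccc2)c(SCc2ccccc2)cc1Cl` gives 5000 nM. Compound 4 `Cc1cc(S(=O)(=O)/N=C(\N)n2nccc2-c2ccccc2)c(SCc2ccccc2C(F)(F)F)cc1Cl` differs from compound 3 by 2-(trifluoromethyl)phenyl in place of 4-methylphenyl on a saturated chain carbon bound to a sulfur. Going by the values given here, two measured steps touch the same place: a 2.1-fold higher number from compound 1 to compound 3 (0.33 log units; beyond the scatter) and a 3.4-fold higher number from compound 2 to compound 3 (0.53 log units; beyond the scatter), both modest. Changes to this aryl group have so far moved the read-out only modestly, and no measured compound carries a trifluoromethyl group, so the size of this step has no direct anchor. The expected step is therefore small, a 1.7-fold lower number from compound 3 to compound 4 (0.23 log units; within the scatter). For compound 4 in this assay the estimate is 10000 nM, between 4000 nM and 30000 nM.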

Compound 4, half-maximal inhibitory concentration: 20000 nM
The estimate for compound 4 lay 2.0-fold (0.30 log units) below the measured number, within the range that was stated.
By their numbers in this assay, from the lowest: compounds 2 and 1 (each within the scatter of the next); then compounds 3 and 4 (each within the scatter of the next).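

In this assay, 2-(trifluoromethyl)phenyl and 4-methylphenyl on a saturated chain carbon bound to a sulfur cannot be told apart, with a 1.2-fold higher number from compound 3 to compound 4 (0.07 log units; within the scatter). Trifluoromethyl in place of hydrogen on an aromatic carbon gives a 4.0-fold higher number from compound 2 to compound 4 (0.60 log units; beyond the scatter), and 2-(trifluoromethyl)phenyl in place of 3-methylphenyl gives a 2.5-fold higher number from compound 1 to compound 4 (0.40 log units; beyond the scatter), so a second compound now stands beyond the scatter of compounds 1 and 2, although compound 1 itself stays within the scatter of compound 2. No evidence here bears on why these numbers fall as they do. As far as these compounds go, whether an amine or a carboxylic acid on this aryl ring would lower the number remains open, as does the effect of a longer chain in place of the benzyl group.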